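Chloro on the Oxindole Ring: Compound 2 to Compound 3

This account rests on a few compounds, and the source may have more. Where it says the series, first, only, none or still open, it means among the compounds named here.

Compound 1 `O=C1/C(=C/c2c(Cl)[nH]c3ccccc23)c2ccccc2N1Cc1ccccc1`: 9120 nM
Compound 2 `COc1c(/C=C2/C(=O)Nc3ccccc32)c2ccccc2n1-c1ccccc1`: 1380 nM

Of the compounds shown here, two have been measured in a functional assay on cells (Cancer cell lines, Homo sapiens) for cytotoxicity, with a stated time of 48 h; on this read-out lower numbers stand for stronger inhibition of growth and higher numbers for weaker inhibition of growth. Compound 2 `COc1c(/C=C2/C(=O)Nc3ccccc32)c2ccccc2n1-c1ccccc1` gives the lower of the two numbers, 1380 nM, while compound 1 gives 9120 nM, a gap that lies beyond the usual scatter. Compound 3 `COc1c(/C=C2/C(=O)Nc3ccc(Cl)cc32)c2ccccc2n1-c1ccccc1` is not yet measured. It differs from compound 2 in one place: chloro in place of hydrogen on an aromatic carbon, which amounts to a chloro in place of hydrogen on an aromatic carbon. Among the compounds with values here, no step between measured compounds of this kind is known here, so the size of the change in this assay cannot be read from the data. The expectation is for a step near the scatter, a 1.4-fold lower number from compound 2 to compound 3 (0.14 log units; within the scatter), with no firm direction. Compound 3 is therefore expected to give about 1000 nM, somewhere between 300 nM and 3500 nM.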

Compound 3, concentration for 50% growth inhibition: 8510 nM
Estimate against measurement, compound 3: 8.5-fold (0.93 log units) below; measured number above the stated range.
By their numbers in this assay, from the lowest: compound 2; then compounds 3 and 1 (each within the scatter of the next).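

In this assay, chloro in place of hydrogen on an aromatic carbon of the six-membered aromatic ring of carbon only is not a silent change: it brings a 6.2-fold higher number from compound 2 to compound 3 (0.79 log units; beyond the scatter), so this position does respond to substitution, and growth inhibition is weaker with chloro than with hydrogen. The earlier compounds shown here could not show this, as they differ in more than one place and offered no single step to read. Nothing available here accounts for the size of this loss.

On these data alone, whether a fluoro, methyl or methoxy group on the same carbon would bring a similar loss stays open. So does whether an amine there, or chloro on another carbon of this ring, would leave the number of compound 2 unchanged.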